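Acylation of an Aryl Amine in a Triazole Series

The compounds below may be only part of what the source reports. "The series", "measured", "known", "first", "only" and "open" are said of these compounds alone.

Measured compounds:
Compound 1 `C/N=C(\S)n1nc(-c2ccccc2)nc1N` — 54%
Compound 2 `C/N=C(\S)n1nc(-c2ccc(C#N)cc2)nc1N` — 87%
Compound 3 `C/N=C(\S)n1nc(-c2ccc(N)cc2)nc1N` — no result reported

Compound 1 and compound 2 share a core and differ only at one aromatic carbon. In a functional assay on the whole organism for inhibition, with Rattus norvegicus as the target, at a dose of 30 mg/kg (a higher number here means more inhibition at the dose given (going by the name of the read-out), a lower number less inhibition), compound 1 gives 54% and compound 2 gives 87%; the step of a number 33 percentage points higher from compound 1 to compound 2 (beyond the scatter) is the only one measured in this set. Compound 3 carries an amino group at the same position on the aryl ring, but for it no number is reported, so it has no place on the scale shown by compound 1 and compound 2.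

Compound 4 `CCOC(=O)C(=O)Nc1ccc(-c2nc(N)n(/C(S)=N/C)n2)cc1` is the next member. It differs from compound 3 by (ethoxycarbonyl)carbonyl in place of hydrogen on a nitrogen on an aromatic ring, that is, amino to ((ethoxycarbonyl)carbonyl)amino. Going by the values given here, no measured step involves a change at this nitrogen, and the only measured step, from a hydrogen to a cyano group on an aromatic carbon, is of a different kind; it shows only that a change at this part of the aryl ring can move the read-out by a large amount. With compound 3 unmeasured there is no anchor, so neither direction nor size of the step can be expected with confidence. Compound 4 is therefore estimated to give 60%, with a range from 25% to 90%.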

Compound 4, a percentage reported as inhibition, in the whole organism at one dose (the size of the read-out at that dose, not a potency): 49%
The estimate for compound 4 lay 11 percentage points above the measured number, and the stated range covers the measured number.
By their numbers in this assay, from the lowest: compounds 4 and 1 (each within the scatter of the next); then compound 2.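

In this assay, the ((ethoxycarbonyl)carbonyl)amino group on this aromatic carbon does not reach the level set by the cyano group (a number 38 percentage points lower from compound 2 to compound 4 (beyond the scatter)). Against hydrogen at the same carbon, the new group cannot be told apart from the parent (a number 5 percentage points lower from compound 1 to compound 4 (within the scatter)). The earlier compounds shown here showed only a rise on replacing hydrogen here, whereas this result shows that the rise does not come with every replacement at this carbon and that a far longer substituent can stand here while the read-out stays within the scatter of the hydrogen compound. Nothing given here bears on the reason for the gap between the cyano and the ((ethoxycarbonyl)carbonyl)amino compounds.

As far as these compounds go, the step from compound 3 to compound 4 cannot be read, so the effect of acylating the amino group itself remains unknown. From the compounds shown here alone, it also remains open whether a carboxylic acid in place of the ethyl ester, or a simple acetyl group on the same nitrogen, would stay at the level of compound 4 or move towards that of compound 2.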